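A few compounds are considered here, and "the series" means these few. Any claim that something is new, unique, unknown or untested is made for them only; others in the source may bear on it.

Of the compounds shown here, three have been measured in a functional assay on THP-1 cells (Homo sapiens) for inhibition, read by ELISA, with stated times of 30 min and 24 h, tested at 1 uM; a higher number here means a stronger effect of the compound at the concentration tested, a lower number a weaker effect. Compound 1 `COc1cc(O)c(C(=O)c2cccc(F)c2)c(OC)c1` gives 38%. Compound 2 `COc1cc(OC)c(C(=O)c2cccc(Cl)c2)c(O)c1CN1CCCCC1` gives 33%, and compound 3 `COc1cc(OC)c(C(=O)c2cccc(Cl)c2)c(O)c1CN1CCCC1` gives 41%. Compound 3 holds the highest of the three numbers, yet its distance to compound 1 and to compound 2 each lies within the scatter, so the three cannot be set in order. Among the compounds with values here, the only single-place step measured, a number 8 percentage points higher from compound 2 to compound 3 (within the scatter), also stays within the scatter.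

Compound 4 `COc1cc(OC)c(C(=O)c2cccc(F)c2)c(O)c1CN1CCCC1` differs from compound 3 by fluoro in place of chloro on an aromatic carbon. Within the data shown here, no measured step bears on this change directly: the step of a number 8 percentage points higher from compound 2 to compound 3 (within the scatter) concerns a different place. Among the measured compounds shown here, compound 1 carries fluoro but differs from compound 3 in more than one place, so no step is known for that pair. What can be said is that compound 1 gives 38% while compound 3 gives 41%, two numbers within the scatter of each other. The step of a number 2 percentage points lower from compound 3 to compound 4 (within the scatter) is therefore expected to remain within the scatter. The estimate for compound 4 is 39%, with a range from 25% to 53%.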

Compound 4, a percentage reported as activity, at one concentration (the size of the read-out at that concentration, not a potency): 34%
Beside the measured number, compound 4's estimate is 5 percentage points above it, within the range that was stated.
By their numbers in this assay, from the lowest: compounds 2, 4, 1 and 3 (each within the scatter of the next).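

In this assay, fluoro in place of chloro, on an aromatic carbon meta to a large group, comes with a number 7 percentage points lower from compound 3 to compound 4 (within the scatter), so the two halogens cannot be told apart at this place. The new compound also gives a single-place reading for the (pyrrolidin-1-yl)methyl group in place of hydrogen, a number 4 percentage points lower from compound 1 to compound 4 (within the scatter), so this group has no effect that can be separated from the scatter of this assay. Nothing at hand offers a reason for either reading.

The compounds shown leave open whether a group other than a halogen at this place, such as a nitrile or methoxy, would give a step beyond the scatter. They also leave open how an open-chain amine such as dimethylamino or a ring such as morpholine would read in place of pyrrolidin-1-yl.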